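This account rests on a few compounds, and the source may have more. Where it says the series, first, only, none or still open, it means among the compounds named here.

Measured in an assay on isolated protein for binding affinity to Leucine-rich repeat serine/threonine-protein kinase 2 (Homo sapiens), read by TR-FRET and LanthaScreen, with a stated time of 2 h; a lower number here means a stronger inhibitor, a higher number a weaker inhibitor:
- compound 1, `CN(C)c1c(C#N)c2c(N)ncnc2n1C`, 111 nM
- compound 2, `Cc1cn(C)nc1Nc1cc2c(c(N)n1)c(C#N)c(N1CCC[C@H]1C)n2C`, 63 nM
- compound 3, `Cn1c(NCc2ccccc2F)c(C#N)c2c(N)ncnc21`, 145 nM

The three numbers lie close together: compound 1 stands between compound 2 and compound 3, and its gap to either is within the usual scatter of this assay, so no order among the three can be read from them.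

Compound 4, `Cn1c(-c2ccccc2)c(C#N)c2c(N)ncnc21`, is not yet measured. It differs from compound 1 in one place: phenyl in place of dimethylamino on an aromatic carbon. Among the measured compounds shown here, no pair of measured compounds shows this kind of exchange, so nothing here says which way the number should move. The expectation is a step from compound 1 of a 1.2-fold higher number from compound 1 to compound 4 (0.07 log units; within the scatter), that is, none beyond the scatter. For compound 4 the estimate in this assay is 130 nM, with a range from 50 nM to 350 nM.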

Compound 4, inhibition constant: 30 nM
Estimate against measurement, compound 4: 4.3-fold (0.64 log units) above, and the stated range ends above it.
By their numbers in this assay, from the lowest: compound 4; then compounds 2, 1 and 3 (each within the scatter of the next, the first and the last beyond it).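

Among the compounds shown here, on the aromatic carbon next to the ring nitrogen, exchanging dimethylamino for phenyl gives a 3.7-fold lower number from compound 1 to compound 4 (0.57 log units; beyond the scatter) in this assay and is the first exchange with a step beyond the scatter. The entering phenyl has no hydrogen-bond acceptor, so an acceptor in this substituent is not needed for the lower number. No available data bear on the cause of this step.

Whether the step depends on an aromatic ring remains open, since a cyclohexyl ring is not among the compounds shown. As far as these compounds go, the effect of a pyridine ring or a fluorophenyl group at this position also remains open.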